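A few compounds are considered here, and "the series" means these few. Any claim that something is new, unique, unknown or untested is made for them only; others in the source may bear on it.

Compounds measured in an assay on CHO cells for displacement of a labelled ligand from 5-hydroxytryptamine receptor 1D (Homo sapiens); on this read-out lower numbers stand for stronger inhibition and higher numbers for weaker inhibition:

- compound 1, `O=S(=O)(NCC1CCN(CCCc2c[nH]c3ccc(-n4cnnc4)cc23)CC1)c1ccccc1` — 6.2 nM
- compound 2, `CN(CC1CCN(CCCc2c[nH]c3ccc(-n4cnnc4)cc23)CC1)C(=O)Nc1ccccc1` — 5.9 nM
- compound 3, `O[C@H]1Cc2ccccc2C1NC1CCN(CCCc2c[nH]c3ccc(-n4cnnc4)cc23)CC1` — 37 nM

Compound 3 carries the highest of the three numbers in this assay: it sits a 6.0-fold higher number from compound 1 to compound 3 (0.78 log units; beyond the scatter) away from compound 1, and compound 2 gives a lower number still, so compound 3 is the weakest of the measured set on this read-out.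

Compound 4, `c1ccc(CNCC2CCN(CCCc3c[nH]c4ccc(-n5cnnc5)cc34)CC2)cc1`, is not yet measured. It differs from compound 3 in one place: (benzylamino)methyl in place of (2-hydroxy-2,3-dihydro-1H-inden-1-yl)amino on a saturated ring carbon. The new group restores the arrangement shared by compounds 1 and 2, in which a saturated chain carbon links the ring carbon to a nitrogen that in turn carries an aromatic-bearing group.

Within the data shown here, two measured steps bear on this change. The step of a 6.0-fold higher number from compound 1 to compound 3 (0.78 log units; beyond the scatter) shows that replacing such a chain-linked group with the hydroxyindanylamino group raised the number modestly; compound 4 reverses that kind of change. The step of a 1.1-fold lower number from compound 1 to compound 2 (0.02 log units; within the scatter) shows that swapping what hangs on the chain nitrogen made no difference beyond the scatter. Taken together, the expectation for compound 4 is a number in this assay close to those of compounds 1 and 2, which means an expected step of a 4.6-fold lower number from compound 3 to compound 4 (0.67 log units; beyond the scatter), toward lower numbers. Compound 4 is therefore estimated at 8 nM, within a range from 3 nM to 25 nM.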

Compound 4, half-maximal inhibitory concentration: 1.6 nM
The estimate for compound 4 lay 5.0-fold (0.70 log units) above the measured number, and the stated range ends above it.
By their numbers in this assay, from the lowest: compound 4; then compounds 2 and 1 (each within the scatter of the next); then compound 3.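

In this assay, among these compounds, putting (benzylamino)methyl in place of (2-hydroxy-2,3-dihydro-1H-inden-1-yl)amino on this saturated ring carbon gives a far larger shift than the earlier compounds suggested (a 23-fold lower number from compound 3 to compound 4 (1.36 log units; beyond the scatter)), taking the number past those of compound 1 and compound 2 rather than merely back to them. The earlier comparison made what hangs on the chain nitrogen look unimportant (a 1.1-fold lower number from compound 1 to compound 2 (0.02 log units; within the scatter)), but compound 4 shows that this part can matter. Benzyl in place of phenylsulfonyl on the amine nitrogen (a 3.9-fold lower number from compound 1 to compound 4 (0.59 log units; beyond the scatter)) and benzylamino in place of methyl(phenylcarbamoyl)amino on the saturated chain carbon (a 3.7-fold lower number from compound 2 to compound 4 (0.57 log units; beyond the scatter)) both give steps beyond the scatter.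

These compounds cannot show whether the gain rests on the benzyl group itself or on the nitrogen no longer carrying a sulfonyl or carbonyl-bearing group, and a simple primary amine or a longer phenylethyl group on the same chain carbon would help to separate the two. Nothing measured here accounts for the lower number of compound 4.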